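Trifluoromethyl on the terminal ring: expected step

This account rests on a few compounds, and the source may have more. Where it says the series, first, only, none or still open, it means among the compounds named here.

In a functional assay on PC-3 cells (Homo sapiens) for inhibition, read by sulforhodamine B assay (on this read-out higher numbers stand for weaker inhibition of growth and lower numbers for stronger inhibition of growth), compound 1 `c1ccc(-c2ccc(-c3ccc(-c4nc5ccccc5[nH]4)cc3)cc2)cc1` gives 41200 nM and compound 2 `Fc1ccc(-c2ccc(-c3ccc(-c4nc5ccccc5[nH]4)cc3)cc2)cc1` gives 41200 nM, so compound 2 stands level with compound 1. The next compound, compound 3 `FC(F)(F)c1ccc(-c2ccc(-c3ccc(-c4nc5ccccc5[nH]4)cc3)cc2)cc1`, carries trifluoromethyl in place of fluoro on an aromatic carbon, para to a large group: trifluoromethyl in place of fluoro on an aromatic carbon. For the measured compounds named here, one measured step bears on this change: no change at the digits printed from compound 1 to compound 2 (within the scatter), with fluoro in place of hydrogen on the same aromatic carbon. Going by the values given here, that step lies within the scatter, but it is the only precedent, and no trifluoromethyl compound has been measured. A step beyond the scatter in either direction is therefore not expected, though the evidence is thin and the range is kept wide. The expected step is a 1.0-fold lower number from compound 2 to compound 3 (0.01 log units; within the scatter). For compound 3 the estimated value is 40000 nM, within an expected range of 18000 nM to 80000 nM.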

Compound 3, concentration for 50% growth inhibition: 45200 nM
The estimate for compound 3 lay 1.1-fold (0.05 log units) below the measured number; the range from low to high includes it.
By their numbers in this assay, from the lowest: compounds 1, 2 and 3 (each within the scatter of the next).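

In this assay, trifluoromethyl on this aromatic carbon gives a 1.1-fold higher number from compound 2 to compound 3 (0.04 log units; within the scatter) and, measured against hydrogen, a 1.1-fold higher number from compound 1 to compound 3 (0.04 log units; within the scatter). For the compounds shown here, until now the only comparison at this carbon was fluoro against hydrogen; the absence of a step beyond the scatter now extends to the 4-(trifluoromethyl)phenyl compound, so hydrogen, fluoro and trifluoromethyl cannot be told apart here in this read-out. No measurement at hand offers an explanation for this flat result.

The compounds shown leave open whether an amine, a carboxylic acid or a longer chain on this carbon would give a step beyond the scatter. They also leave open whether a change elsewhere on the shared core would move the number beyond the scatter, since all three compounds differ only at this one carbon.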